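The source may hold more compounds than are shown below. What is called first, only, known or untested is meant among the compounds shown, and "the series" means these compounds.

Three compounds have been measured so far in a functional assay on MCF7 cells (Homo sapiens) for inhibition, read by MTT assay, with a stated time of 3 days; on this read-out higher numbers stand for weaker inhibition and lower numbers for stronger inhibition:
- compound 1 `COc1cccc(/C=C/CCCOc2cc(/C=C\c3cc(OC)c(OC)c(OC)c3)ccc2OC)c1` gives 41000 nM
- compound 2 `COc1ccc(/C=C/CCCOc2cc(/C=C\c3cc(OC)c(OC)c(OC)c3)ccc2OC)cc1` gives 16000 nM
- compound 3 `COCOc1ccccc1/C=C/CCCOc1cc(/C=C\c2cc(OC)c(OC)c(OC)c2)ccc1OC` gives 4400 nM

Compound 3, at 4400 nM as its reading, has the lowest number of the three, and its steps to both others lie beyond the scatter. Compound 4 `COCOc1ccc(/C=C/CCCOc2cc(/C=C\c3cc(OC)c(OC)c(OC)c3)ccc2OC)cc1` has the same atoms as compound 3, joined differently: 4-(methoxymethoxy)phenyl in place of 2-(methoxymethoxy)phenyl on a double-bonded chain carbon bound to a double-bonded chain carbon is the whole change, with 4-(methoxymethoxy)phenyl in place of 2-(methoxymethoxy)phenyl on a double-bonded chain carbon bound to a double-bonded chain carbon.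

For the measured compounds named here, no measured step makes exactly this change, so the evidence is indirect. The closest is a 3.6-fold lower number from compound 2 to compound 3 (0.56 log units; beyond the scatter), since compound 2 also carries its group as a 4-substituted phenyl. Also relevant are a 9.3-fold lower number from compound 1 to compound 3 (0.97 log units; beyond the scatter) and a 2.6-fold lower number from compound 1 to compound 2 (0.41 log units; beyond the scatter), which show that replacing this aryl group has moved the number each time. On that basis, a modest rise in the number is expected, leaving compound 4 weaker than compound 3 and probably near compound 2. The expected change is a 2.5-fold higher number from compound 3 to compound 4 (0.40 log units; beyond the scatter) in this assay. For compound 4 the estimated value is 11000 nM, with an expected range from 4000 nM to 30000 nM overall.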

Compound 4, half-maximal inhibitory concentration: 42000 nM
Compound 4: middle estimate off by 3.8-fold (0.58 log units), on the low side, and the stated range ends below it.
By their numbers in this assay, from the lowest: compound 3; then compound 2; then compounds 1 and 4 (each within the scatter of the next).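

In this assay, shifting the methoxymethoxy group from 2-(methoxymethoxy)phenyl to 4-(methoxymethoxy)phenyl, on a double-bonded chain carbon bound to a double-bonded chain carbon, gives the largest upward step seen for a change of atom arrangement alone (a 9.5-fold higher number from compound 3 to compound 4 (0.98 log units; beyond the scatter)), so among these compounds the low number of compound 3 goes with the 2-(methoxymethoxy)phenyl group and not with the methoxymethoxy group wherever it sits. Carrying the group as 4-(methoxymethoxy)phenyl rather than 4-methoxyphenyl does not lower the number but raises it (a 2.6-fold higher number from compound 2 to compound 4 (0.42 log units; beyond the scatter)), which shows that the larger group alone brings no gain. Against 3-methoxyphenyl, 4-(methoxymethoxy)phenyl makes no difference that can be told apart (a 1.0-fold higher number from compound 1 to compound 4 (0.01 log units; within the scatter)), and nothing at hand gives a reason for any of these steps.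

The compounds shown leave open whether a 2-methoxyphenyl or a 2-hydroxyphenyl group at this place would keep the number of compound 3, and where a 3-(methoxymethoxy)phenyl group would fall. They also leave open how an amine or a carboxylic acid on this ring would read in this assay.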